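This account rests on a few compounds, and the source may have more. Where it says the series, first, only, none or still open, it means among the compounds named here.

Of the compounds shown here, three sharing one core have been tested in an ADME assay on HEL cells (Homo sapiens) for cytotoxicity, with a stated time of 3 days; a lower number here means that less compound is tolerated, a higher number that more compound is tolerated. Compound 1 `CCC1(Cc2ccccc2)OS(=O)(=O)C=C1OCc1ccc(F)cc1` stands at a limit of the assay rather than at a number: in this assay compound 1 gives > 50000 nM. Compound 2 `CC1(C(c2ccccc2)c2ccccc2)OS(=O)(=O)C=C1OCc1ccccc1` gives 200000 nM in this assay. Compound 3 `CC(C)C1(Cc2ccccc2)OS(=O)(=O)C=C1OCc1ccccc1` gives 200000 nM in this assay. Compound 4 `CCC1(Cc2ccccc2)OS(=O)(=O)C=C1OCCc1ccccc1` has not yet been measured. It differs from compound 1 in a single place: benzyl in place of 4-fluorophenyl on a saturated chain carbon bound to an oxygen on an unsaturated carbon. Going by the values given here, no measured pair differs in just one place, so no step of known size is available as a guide. Given that compound 1 reaches (the limit of > 50000 nM in this assay, at which 1 of the 3 values shown sits), the change is expected to shift the value by no more than the usual scatter, in no settled direction. Compound 4 is therefore expected to give about 120000 nM, within 50000 nM to 300000 nM, an expected step that the limit leaves unreadable from compound 1 to compound 4.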

Compound 4, half-maximal cytotoxic concentration: 48000 nM
Beside the measured number, compound 4's estimate is 2.5-fold (0.40 log units) above it; the whole stated range lies above it.
By their numbers in this assay, from the lowest: compound 4; then compounds 2 and 3 (each within the scatter of the next).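

With phenethyl in place of 4-fluorobenzyl, this position gives a measured number rather than a limit, so the change can be read at least in part. In this assay compound 1 gives > 50000 nM, which is a limit of the assay and not a number. The swap can therefore be stated only as an at least 1.0-fold lower number from compound 1 to compound 4 (0.01 log units; that floor lies within the scatter), and its true size stays unknown: the limit of > 50000 nM in this assay, at which 1 of the 4 values shown sits.

The compounds shown leave open how a group of another kind at this place, such as an amine or a carboxylic acid, would move the number. They also leave open whether a longer chain would do so.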